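Removing one methoxy from the second aryl ring of compound 2

This account rests on a few compounds, and the source may have more. Where it says the series, first, only, none or still open, it means among the compounds named here.

Of the compounds shown here, two have been measured in a functional assay on SGC-7901 cells (Homo sapiens) for antiproliferative activity, read by MTT assay, with a stated time of 72 h; on this read-out lower numbers stand for stronger inhibition and higher numbers for weaker inhibition. Compound 1 `COc1ccc(-c2nn3c(-c4ccc(OC)c(OC)c4OC)nnc3s2)cc1` gives 3750 nM in this assay. Compound 2 `COc1ccc(-c2nn3c(-c4ccc(OC)c(OC)c4OC)nnc3s2)cc1N`, which carries an amino group on one aryl ring, gives 62 nM. Among the measured compounds shown here, the single measured step, a 60-fold lower number from compound 1 to compound 2 (1.78 log units; beyond the scatter), is the only comparison available. On these two numbers compound 2 stands lowest, with compound 1 the nearest neighbour at a much higher value.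

Compound 3 `COc1ccc(-c2nn3c(-c4ccc(OC)c(OC)c4)nnc3s2)cc1N` differs from compound 2 by hydrogen in place of methoxy on an aromatic carbon. For the measured compounds named here, no measured step involves this position: the one known step, a 60-fold lower number from compound 1 to compound 2 (1.78 log units; beyond the scatter), concerns the amino group on the other ring and gives no direct guidance on the methoxy being removed here. The expectation therefore rests on the unchanged shared core and the retained amino group of compound 2, whose value 62 nM sets the anchor. A modest weakening is expected, with the step of a 2.4-fold higher number from compound 2 to compound 3 (0.38 log units; beyond the scatter) likely near the edge of the scatter rather than large. Compound 3 is thus estimated at 150 nM in this assay, within a range of 40 nM to 600 nM.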

Compound 3, half-maximal inhibitory concentration: 83 nM
The estimate for compound 3 lay 1.8-fold (0.26 log units) above the measured number; measured number inside the range.
By their numbers in this assay, from the lowest: compounds 2 and 3 (each within the scatter of the next); then compound 1.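

In this assay, hydrogen in place of methoxy on the aromatic carbon ortho to a large group gives a 1.3-fold higher number from compound 2 to compound 3 (0.13 log units; within the scatter). Among the compounds shown here, this is the first measured step on the second aryl ring, and it shows that, with the amino group kept on the other ring, this methoxy can be lost without a difference the assay can resolve; at this position, methoxy and hydrogen cannot be told apart on these numbers. No independent data on these compounds bear on the reason for this result.

Open, as far as these compounds go, is whether a hydroxy group, a chlorine atom or a longer chain such as ethoxy on this carbon would read like methoxy and hydrogen, or whether the position is sensitive to groups of other kinds. Also open, from the compounds shown here alone, is whether the other methoxy groups on this ring can be exchanged for hydrogen as freely, and whether the same exchange holds on a compound without the amino group.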